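A few compounds are considered here, and "the series" means these few. Any claim that something is new, unique, unknown or untested is made for them only; others in the source may bear on it.

Measured compounds:
- compound 1 `CN(C)c1ncnc2c1ncn2Cc1ccc(F)cc1`: in a functional assay on the whole organism for inhibition, with Rattus norvegicus as the target, at a dose of 25 mg/kg by the intraperitoneal route (a lower number here means less inhibition, a higher number more inhibition at the dose given (going by the name of the read-out)), compound 1 gives 21%
- compound 2 `CN(C)c1ncnc2c1ncn2Cc1ccc([N+](=O)[O-])cc1`: compound 2 gives 0%
- compound 3 `CN(C)c1ncnc2c1ncn2Cc1ccc(C#N)cc1`: compound 3 gives 0%

Compound 2 stands level with compound 3 at the digits reported, the two together being the lowest of the three numbers; the step of no change at the digits printed from compound 2 to compound 3 (within the scatter) lies within the scatter. Compound 1 is the furthest from it: the step of a number 21 percentage points lower from compound 1 to compound 2 (beyond the scatter) lies beyond the scatter, as does a number 21 percentage points lower from compound 1 to compound 3 (beyond the scatter).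

The next compound is compound 4 `CN(C)c1ncnc2c1ncn2Cc1ccc(O)cc1`. Against compound 2 the change is hydroxy in place of nitro on an aromatic carbon.

Going by the values given here, no measured step involves a hydroxy group, so none bears directly on this change. The two steps that do exist from compound 1, both of the same modest size, show that replacing the fluoro by a nitro or a cyano group takes the read-out down to the floor, and the step between compound 2 and compound 3 shows no difference between those two groups. From compound 2, at zero, the read-out cannot fall further; a hydroxy group may leave it there or lift it somewhat, and the data give no basis for a large rise. The step of a number 8 percentage points higher from compound 2 to compound 4 (within the scatter) is therefore expected to be small. For compound 4 the estimate is 8%, with a range of 0% to 25%.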

Compound 4, a percentage reported as inhibition, in the whole organism at one dose (the size of the read-out at that dose, not a potency): 0%
For compound 4 the middle estimate is 8 percentage points above the measured one; the measured number falls inside the stated range.
By their numbers in this assay, from the lowest: compounds 2, 3 and 4 (each within the scatter of the next); then compound 1.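

In this assay, hydroxy in place of nitro gives no change at the digits printed from compound 2 to compound 4 (within the scatter), and hydroxy in place of cyano gives no change at the digits printed from compound 3 to compound 4 (within the scatter), so on this aromatic carbon, para to a large group, three different groups now read alike. The hydroxy group brings a hydrogen-bond donor, which nitro lacks, and at this dose that difference leaves the read-out where it was. Hydroxy in place of fluoro gives a number 21 percentage points lower from compound 1 to compound 4 (beyond the scatter), which leaves compound 1 as the only member of the series shown that stands clear of the others, and no measurement at hand accounts for this separation.

Going by these compounds alone, with only one dose and three compounds sharing the same printed value, the assay cannot separate nitro, cyano and hydroxy from one another, and any differences among them at other doses remain unknown. As far as these compounds go, it also remains open whether the fluoro result is specific to that atom or would be shared by plain hydrogen, chloro, methoxy or an amine on the same carbon, and whether any such group would rise above compound 1.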